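Ester-bearing piperidine analogue in the cyclic carbamate series

The compounds below may be only part of what the source reports. "The series", "measured", "known", "first", "only" and "open" are said of these compounds alone.

Compound 3 `O=C1O[C@@H](CN2CCCCC2)CN1c1ccc(-n2cc(-c3ccccn3)cn2)c(F)c1` sits at the top of what the read-out can show. In an ADME assay on L02 cells (Homo sapiens) for cytotoxicity, read by MTT assay, with a stated time of 48 h (on this read-out higher numbers stand for weaker inhibition and lower numbers for stronger inhibition), compound 3 gives > 400 ug/mL, which is a limit of the assay and not a number. This is the limit described by the limit of > 400 ug/mL in this assay, at which 2 of the 3 values shown sit. Compound 1 `CN(CCC#N)C[C@H]1CN(c2ccc(-n3cc(-c4ccccn4)cn3)c(F)c2)C(=O)O1` also gives a limit; in this assay compound 1 gives > 400 ug/mL. Compound 2 `CCN1CCN(C[C@H]2CN(c3ccc(-n4cc(-c5ccccn5)cn4)c(F)c3)C(=O)O2)CC1` gives 99 ug/mL in this assay. The readable steps, an at least 4.0-fold lower number from compound 1 to compound 2 (0.60 log units; beyond the scatter) and an at least 4.0-fold higher number from compound 2 to compound 3 (0.60 log units; beyond the scatter), exchange the whole amine on the chain carbon, while a step that the two limits leave unreadable from compound 1 to compound 3. Among the measured compounds shown here, compound 4 `COC(=O)CC1CCN(C[C@H]2CN(c3ccc(-n4cc(-c5ccccn5)cn4)c(F)c3)C(=O)O2)CC1` differs from compound 3 by (methoxycarbonyl)methyl in place of hydrogen on a saturated ring carbon, a change none of the measured steps covers. Compound 4 is therefore expected to remain near the limit, estimated at 400 ug/mL with a range of 200 ug/mL to 800 ug/mL. For compound 4 this means an expected step of a number no higher from compound 3 to compound 4 (the limit leaves the size open).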

Compound 4, half-maximal inhibitory concentration: > 400 ug/mL
Compound 4 was reported as a limit; the forecaster's own chance of this, stated with the estimate: 70%; the middle value sits exactly at the limit.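

In this assay compound 4 gives > 400 ug/mL, which is a limit of the assay and not a number. Among the compounds shown here, replacing 4-ethylpiperazin-1-yl with 4-((methoxycarbonyl)methyl)piperidin-1-yl gives an at least 4.0-fold higher number from compound 2 to compound 4 (0.60 log units; beyond the scatter), so a piperidin-1-yl carrying this substituent also stands clear of the only measured number. The steps between compounds at the limit cannot be read, which leaves (methoxycarbonyl)methyl in place of hydrogen without a size: the limit of > 400 ug/mL in this assay, at which 3 of the 4 values shown sit.

Open, as far as these compounds go, is whether a carboxylic acid in place of the methyl ester, or a piperazine bearing an acetyl group, would bring the number within the readable range.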